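The source may report more compounds than this note shows. Statements on the series, on what has been measured and on what is new or still open speak of the compounds shown alone.

Compound 1 `O=S(=O)(c1ccc(F)cc1)N1CC(c2nc(-c3cccc(Cl)c3)no2)C1`: > 10000 nM
Compound 2 `O=C(C1CCC(C(F)(F)F)CC1)N1CC(c2nc(-c3cccc(F)c3)no2)C1`: 680 nM
Compound 3 `O=C(C1CCC(C(F)(F)F)CC1)N1CC(c2nc(-c3cccc(Cl)c3)no2)C1`: 1000 nM

Of the compounds shown here, three have been measured in an assay on HEK293 cells for positive allosteric modulation of metabotropic glutamate receptor 5 (Homo sapiens), read by FLIPR; a lower number here means that less compound is needed, a higher number that more compound is needed for the effect. Compound 2 gives 680 nM and compound 3 gives 1000 nM. For compound 1 this assay returns only a limit, > 10000 nM, and no number. How the core of compound 1 differs from that of compound 2 is not broken down here.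

Compound 3 differs from compound 2 in one place, (chloro in place of fluoro on an aromatic carbon). That step is a 1.5-fold higher number from compound 2 to compound 3 (0.17 log units; within the scatter).

Compound 4 `O=S(=O)(c1ccc(Cl)cc1)N1CC(c2nc(-c3cccc(Cl)c3)no2)C1` has not yet been measured. It differs from compound 1 by chloro in place of fluoro on an aromatic carbon. Within the data shown here, this is the same kind of change as the one from compound 2 to compound 3, though the surroundings are not the same: in compound 4 the entering chloro sits para to a large group, whereas in compound 3 it sits meta to a large group.

The expectation for compound 4 is a step that the limit leaves unreadable from compound 1 to compound 4, which rests on the measured step of a 1.5-fold higher number from compound 2 to compound 3 (0.17 log units; within the scatter) being within the scatter. Compound 1 sits at the limit (the limit of > 10000 nM in this assay, at which 1 of the 3 values shown sits). Compound 4 is therefore expected to give about 15000 nM, between 5000 nM and 50000 nM, most probably again only a limit.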

Compound 4, half-maximal effective concentration: > 10000 nM
Compound 4: a limit, no number; the forecaster's own chance of this, stated with the estimate: 85%; the middle value is on the limit's open side.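

Compound 1 and compound 4 both return only a limit in this assay, so no step can be read between them for the change from 4-fluorophenyl to 4-chlorophenyl: the limit of > 10000 nM in this assay, at which 2 of the 4 values shown sit.

The compounds shown leave open what number either compound would give, and whether chloro in place of fluoro acts here as it does between compound 2 and compound 3.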